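Swapping dipropylamino for a branched secondary amine

The compounds below may be only part of what the source reports. "The series", "measured", "known", "first", "only" and "open" are said of these compounds alone.

In an assay on HEK293-TREx cells for antagonist activity at transient receptor potential cation channel subfamily A member 1 (Homo sapiens), read by calcium flux (a higher number here means a weaker inhibitor, a lower number a stronger inhibitor), compound 1 `COC(=O)Nc1cc(NC(=O)c2cccs2)cc(C(F)(F)F)c1` gives 2300 nM. Compound 2 `CCCN(CCC)c1cc(NC(=O)c2cccs2)cc(C(F)(F)F)c1` reaches only a limit of this assay, > 32000 nM, so no exact number is known for it. Within the data shown here, the one measured step that bears on the next change is an at least 13-fold higher number from compound 1 to compound 2 (1.14 log units; beyond the scatter), which ends at the limit of > 32000 nM in this assay, at which 1 of the 2 values shown sits. Compound 3 `CC(C)C(C)Nc1cc(NC(=O)c2cccs2)cc(C(F)(F)F)c1` differs from compound 2 by (1,2-dimethylpropyl)amino in place of dipropylamino on an aromatic carbon. Among the measured compounds shown here, with only a limit as the starting point and no measured step of this exact kind, compound 3 is estimated to sit near 20000 nM, between 5000 nM and 60000 nM, an expected step of an at least 1.6-fold lower number from compound 2 to compound 3 (0.20 log units; that floor lies within the scatter).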

Compound 3, half-maximal inhibitory concentration: 1300 nM
Estimate against measurement, compound 3: 15-fold (1.19 log units) above, and the stated range ends above it.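

On this aromatic carbon, not every amine ends at the limit in this assay: an at least 24-fold lower number from compound 2 to compound 3 (1.39 log units; beyond the scatter). Compound 3 also shows that a nitrogen carrying 1,2-dimethylpropyl can match one carrying methoxycarbonyl: a 1.8-fold lower number from compound 1 to compound 3 (0.25 log units; within the scatter). The first of these steps has only one firm end, as the value of compound 2 is a limit and not a number: the limit of > 32000 nM in this assay, at which 1 of the 3 values shown sits.

The change from dipropylamino adds a hydrogen-bond donor and a branched chain at once, and the compounds shown do not separate the two. An unbranched propylamino group at this position would tell them apart.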